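Dimethylamino for fluoro on two related quinazolinone cores

The source may hold more compounds than are shown below. What is called first, only, known or untested is meant among the compounds shown, and "the series" means these compounds.

Of the compounds shown here, three have been measured in an assay on isolated protein for inhibition of DNA topoisomerase 1 (Homo sapiens), with a stated time of 30 min, tested at 100 uM; on this read-out lower numbers stand for a weaker effect and higher numbers for a stronger effect at the one concentration tested. Compound 1 `Cc1ccc2nc(-c3ccccc3N(C)C)[nH]c(=O)c2c1` gives 82.9%, compound 2 `Cc1ccc2c(=O)[nH]c(-c3ccccc3F)nc2c1` gives 81.2%, and compound 3 `Cc1ccc2nc(-c3ccccc3F)[nH]c(=O)c2c1` gives 67.9%. Compound 2 and compound 3 hold the same atoms joined differently; the difference between the two cores is not broken down here. Their numbers lie apart beyond the scatter, with compound 3 the lower of the two. Compound 1 and compound 2 lie within the scatter of each other, so no order is claimed between them.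

Compound 1 arises from compound 3 by one change, (dimethylamino in place of fluoro on an aromatic carbon), and this change made a step of a number 15 percentage points higher from compound 3 to compound 1 (beyond the scatter), a modest rise beyond the scatter.

Compound 4 `Cc1ccc2c(=O)[nH]c(-c3ccccc3N(C)C)nc2c1` has not yet been measured. It arises from compound 2 by the same change, (dimethylamino in place of fluoro on an aromatic carbon), on the same kind of place, as the place descriptions of the two changes agree word for word. Among the compounds with values here, only one occurrence of this change has been measured, so any transfer to the core of compound 2 rests on a single example.

Compound 4 is expected to show a step of a number 8.8 percentage points higher from compound 2 to compound 4 (within the scatter) in this assay, smaller than the earlier one, since the expectation rests on a number 15 percentage points higher from compound 3 to compound 1 (beyond the scatter) while the starting value of compound 2, 81.2%, already stands close to full inhibition, which the read-out cannot exceed. Compound 4 is therefore estimated at 90%, with a likely range from 80% to 98%.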

Compound 4, a percentage reported as inhibition, at one concentration (the size of the read-out at that concentration, not a potency): 82.1%
The estimate for compound 4 lay 7.9 percentage points above the measured number, within the range that was stated.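

In this assay, the same change of fluoro to dimethylamino on the second core made a step of a number 0.9 percentage points higher from compound 2 to compound 4 (within the scatter), so the rise seen on the first core did not carry over in size. Set side by side, the two occurrences of this one change disagree: the same change on two cores in this assay, a number 15 percentage points higher (beyond the scatter) from compound 3 to compound 1 and a number 0.9 percentage points higher (within the scatter) from compound 2 to compound 4, 14.1 percentage points apart, beyond the scatter of two such steps. Within the data shown here, this shows that the size of the step cannot simply be taken from one core to the other, but with only one pair on each core it does not show what sets the two cores apart, nor how the change would behave on any further core.

The compounds shown leave open whether other groups on that aromatic carbon, such as an amine, a methoxy group or a longer chain, would follow the step seen on one core or on the other. They also leave open how either core would respond to a change elsewhere, for instance a carboxylic acid in place of the methyl group, and whether the order of stronger and weaker effects seen at this one concentration would hold at other concentrations.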